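Moving an amino group onto a second benzyl-purine core

This account rests on a few compounds, and the source may have more. Where it says the series, first, only, none or still open, it means among the compounds named here.

Measured compounds:
Compound 1, `ClCc1ccccc1Cn1cnc2c(Cl)nc(Cl)nc21`, 200 nM
Compound 2, `ClCc1cccc(Cn2cnc3c(Cl)nc(Cl)nc32)c1`, 3380 nM
Compound 3, `Nc1nc(Cl)c2ncn(Cc3ccccc3CCl)c2n1`, 5130 nM

All three were tested in a functional assay on MOLT-4 cells (Homo sapiens) for cytotoxicity, read by sulforhodamine B assay, with a stated time of 48 h; a higher number here means a weaker inhibitor of growth, a lower number a stronger inhibitor of growth. Compound 1 gives 200 nM, and compound 3, which carries an amino in place of chloro on an aromatic carbon, gives 5130 nM, so that a 26-fold higher number from compound 1 to compound 3 (1.41 log units; beyond the scatter). Compound 2 gives 3380 nM; how its core differs from that of compound 1 is not broken down here, and the two values simply show a higher number for compound 2 than for compound 1.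

Compound 4, `Nc1nc(Cl)c2ncn(Cc3cccc(CCl)c3)c2n1`, has not yet been measured. It differs from compound 2 by amino in place of chloro on an aromatic carbon, the same change that leads from compound 1 to compound 3. If that step carries over to the core of compound 2, a step of about a 12-fold higher number from compound 2 to compound 4 (1.07 log units; beyond the scatter) is expected in this assay, resting on a 26-fold higher number from compound 1 to compound 3 (1.41 log units; beyond the scatter) and on the value of compound 2, 3380 nM. Compound 4 is therefore estimated at 40000 nM, within roughly 10000 nM to 150000 nM.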

Compound 4, concentration for 50% growth inhibition: 4780 nM
Compound 4: the middle estimate sits 8.4-fold (0.92 log units) above what was measured, outside the stated range (below it).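

In this assay, putting amino in place of chloro on an aromatic carbon of the core of compound 2 gives a 1.4-fold higher number from compound 2 to compound 4 (0.15 log units; within the scatter), a step too small to tell apart from the scatter of repeated measurements. The change therefore cannot be carried from one core to the other at a fixed size, as the two steps do not agree: the same change on two cores in this assay, a 26-fold higher number (1.41 log units; beyond the scatter) from compound 1 to compound 3 and a 1.4-fold higher number (0.15 log units; within the scatter) from compound 2 to compound 4, 18-fold (1.26 log units) apart, beyond the scatter of two such steps. This shows only that the size of the step depends on the core in this one pair of cores; it does not show what in the cores sets the size, or which of the two steps would be more typical of other cores in this series.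

As far as these compounds go, it remains open whether other groups on the same aromatic carbon, such as a methylamino or a methoxy group, would follow the large step of the core of compound 1 or the small one of the core of compound 2. From the compounds shown here alone, it also remains open which of the two steps a third core would resemble.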